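The source may report more compounds than this note shows. Statements on the series, on what has been measured and on what is new or still open speak of the compounds shown alone.

Of the compounds shown here, two built on one shared core have been tested in a functional assay on PC-3 cells (Homo sapiens) for inhibition; a higher number here means a weaker inhibitor, a lower number a stronger inhibitor. Compound 1 `COc1ccc(C(=O)N2CCN(c3nc(N)c4cc(OC)c(OC)cc4n3)CC2)cc1OC` gives 71000 nM, and compound 2 `COc1cc2nc(N3CCN(S(=O)(=O)c4ccc([N+](=O)[O-])cc4)CC3)nc(N)c2cc1OC` gives 36000 nM. Compound 2 carries the lower of these two numbers, but the gap between them lies within the usual scatter, so neither compound stands apart. Compound 3 `COc1cc2nc(N3CCN(S(=O)(=O)c4ccc5ccccc5c4)CC3)nc(N)c2cc1OC` differs from compound 2 in one place: naphthalen-2-yl in place of 4-nitrophenyl on a sulfonyl sulfur. Among the measured compounds shown here, no measured pair shows what such an exchange does on this core, so the expectation rests on compound 2 alone. Compound 3 is expected to give about 30000 nM, somewhere between 10000 nM and 90000 nM. The expected step of a 1.2-fold lower number from compound 2 to compound 3 (0.08 log units; within the scatter) stays within the scatter.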

Compound 3, half-maximal inhibitory concentration: 15000 nM
Beside the measured number, compound 3's estimate is 2.0-fold (0.30 log units) above it, within the range that was stated.
By their numbers in this assay, from the lowest: compound 3; then compounds 2 and 1 (each within the scatter of the next).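

Putting naphthalen-2-yl in place of 4-nitrophenyl on the sulfonyl sulfur gives a 2.4-fold lower number from compound 2 to compound 3 (0.38 log units; beyond the scatter) in this assay, a modest step but the first one here that rises above the scatter. It shows that the number in this assay can respond to the group on this sulfur. No measurement shown here accounts for the step.

The exchange removes the nitro group and adds a second ring at once, so one step cannot tell these two changes apart. As far as these compounds go, how a plain phenyl, or a phenyl carrying an amine or a carboxylic acid, would behave at this place remains open.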